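The compounds below may be only part of what the source reports. "The series", "measured", "known", "first", "only" and "open" are said of these compounds alone.

Going by the values given here, compound 2 `CCCSc1nc(N/N=C(\C)c2ccccc2O)c2nnn(Cc3ccc(O)cc3)c2n1` holds the lower of the two numbers so far in a functional assay on MCF7 cells (Homo sapiens) for antiproliferative activity, read by MTT assay, with a stated time of 72 h (a lower number here means a stronger inhibitor, a higher number a weaker inhibitor), where compound 2 gives 9520 nM; its nearest neighbour is compound 1 `CCCSc1nc(N/N=C(\C)c2ccccc2O)c2nnn(Cc3ccc(Cl)cc3)c2n1`, which in this assay gives 42600 nM. Among the compounds with values here, the only measured step in the set is a 4.5-fold lower number from compound 1 to compound 2 (0.65 log units; beyond the scatter). Compound 3 `CCCSc1nc(N/N=C(\C)c2ccccc2O)c2nnn(Cc3ccc(F)cc3)c2n1` differs from compound 2 by fluoro in place of hydroxy on an aromatic carbon. That measured step bears on this change in reverse: it shows the number falling when a halogen on that aromatic carbon gives way to hydroxy, and here the hydroxy gives way to a halogen again, so a rise in this assay is expected. Within the data shown here, no step in this set links fluoro to chloro, so the size of the rise is uncertain. The step expected in this assay is a 2.6-fold higher number from compound 2 to compound 3 (0.42 log units; beyond the scatter). Compound 3 is estimated at 25000 nM in this assay, with a range from 9000 nM to 65000 nM.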

Compound 3, half-maximal inhibitory concentration: > 64000 nM
Compound 3 ended at the assay's limit; the forecaster's own chance of this, stated with the estimate: 10%; middle value at least 2.5-fold (0.40 log units) from the limit.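

In this assay compound 3 stands only as a limit of the assay, not as a number: the limit of > 64000 nM in this assay, at which 1 of the 3 values shown sits.

Fluoro in place of hydroxy at this aromatic carbon gives an at least 6.7-fold higher number from compound 2 to compound 3 (0.82 log units; beyond the scatter), so both halogens shown now lie on the weak side of the hydroxy, and the step from hydroxy is beyond the scatter in each case. Fluoro in place of chloro gives an at least 1.5-fold higher number from compound 1 to compound 3 (0.17 log units; that floor lies within the scatter); that floor lies within the scatter, so the two halogens cannot be put in order from these readings.

From the compounds shown here alone, whether the advantage is specific to hydroxy stays open, as an amine, a methoxy or a carboxylic acid at the same place would be needed to tell. Also open, going by these compounds, is whether the hydroxy keeps its advantage with a longer chain elsewhere on the shared core.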